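Swapping tert-butyl for chloro on compound 1

This account rests on a few compounds, and the source may have more. Where it says the series, first, only, none or still open, it means among the compounds named here.

- compound 1 `CC(C)(C)c1ccc(OCCCON2C(N)=NC(N)=NC23CCSCC3)cc1` gives 280 nM
- compound 2 `COc1ccc(OCCCON2C(N)=NC(N)=NC23CCOCC3)cc1` gives 1670 nM

Both numbers come from a functional assay on HL-60 cells (Homo sapiens) for antiproliferative activity, read by MTT assay, with a stated time of 72 h (on this read-out lower numbers stand for stronger inhibition and higher numbers for weaker inhibition), and compound 1 holds the lower one, with compound 2 higher by a gap beyond the usual scatter. These two differ in more than one place, so no single change can be read from them. Compound 3 `NC1=NC2(CCSCC2)N(OCCCOc2ccc(Cl)cc2)C(N)=N1` keeps the core of compound 1 with one change, chloro in place of tert-butyl on an aromatic carbon. Among the measured compounds shown here, no measured step covers this change, so the expectation is loose: a moderate rise in the number, meaning weaker inhibition (a 2.1-fold higher number from compound 1 to compound 3 (0.33 log units; beyond the scatter)). For compound 3 the estimate is 600 nM with an expected range from 200 nM to 1800 nM in this test.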

Compound 3, half-maximal inhibitory concentration: 430 nM
Compound 3: the middle estimate sits 1.4-fold (0.14 log units) above what was measured; the measured number falls inside the stated range.
By their numbers in this assay, from the lowest: compounds 1 and 3 (each within the scatter of the next); then compound 2.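

In this assay chloro in place of tert-butyl on an aromatic carbon gives a 1.5-fold higher number from compound 1 to compound 3 (0.19 log units; within the scatter) and so leaves compound 1 and compound 3 level in this test. This position therefore accepts either a group of 4 heavy atoms or a single chlorine atom with no clear difference, something compound 2 could not show, as it differs from compound 1 in more than one place. Nothing measured here bears on the reason for this result. As far as these compounds go, whether an amine or a carboxylic acid at this position would fit equally well remains open. So does whether chloro would do the same on the core of compound 2.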